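Nitro for Methoxy on a Weak Adenosine Ligand

The source may report more compounds than this note shows. Statements on the series, on what has been measured and on what is new or still open speak of the compounds shown alone.

Compound 3 `COc1ccc(CNC(=O)c2cnc3nc(C)ccc3c2O)cc1` carries a 4-methoxyphenyl group on the chain bound to its amide nitrogen. In an assay for binding affinity to adenosine receptor A1 (Bos taurus) (a lower number here means a stronger inhibitor, a higher number a weaker inhibitor), compound 3 gives only a limit, > 10000 nM, and no number. Compound 2 `Cc1ccc2c(O)c(C(=O)NCCC(C)C)cnc2n1`, with isobutyl in that place, also gives only a limit in this assay: > 10000 nM. Both thus sit at the limit of > 10000 nM in this assay, at which 2 of the 3 values shown sit, and a step that the two limits leave unreadable from compound 2 to compound 3. Compound 1 `Cc1ccc2c(N=[N+]=[N-])c(Cc3ccccc3)cnc2n1`, built differently, gives 3340 nM in this assay. Compound 4 `Cc1ccc2c(O)c(C(=O)NCc3ccc([N+](=O)[O-])cc3)cnc2n1` differs from compound 3 by nitro in place of methoxy on an aromatic carbon. Within the data shown here, the only measured step near this part of the molecule is the unreadable one from compound 2 to compound 3, so no size or direction can be drawn from it. Compound 4 is therefore expected to stay near the limit, at an estimated 15000 nM, ranging from 4000 nM to 60000 nM. That corresponds to an expected step that the limit leaves unreadable from compound 3 to compound 4.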

Compound 4, inhibition constant: 1630 nM
Compound 4: the middle estimate sits 9.2-fold (0.96 log units) above what was measured; the measured number lies below the stated range.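

Nitro in place of methoxy on this aromatic carbon, para to a large group, gives in this assay an at least 6.1-fold lower number from compound 3 to compound 4 (0.78 log units; beyond the scatter). Among these compounds, the earlier amides showed only limits, so this is the first sign that a change at this position can be read at all. The step is a minimum, because compound 3 has only a limit of the assay: the limit of > 10000 nM in this assay, at which 2 of the 4 values shown sit.

Only methoxy and nitro appear at this position. Going by these compounds, whether an amine or a carboxylic acid there would give a similar number remains open, as does the effect of nitro elsewhere on the ring.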